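A Ring Nitrogen Substituent Changed: Compound 3 to Compound 4

The compounds below may be only part of what the source reports. "The series", "measured", "known", "first", "only" and "open" are said of these compounds alone.

Measured compounds:
Compound 1 `Cn1c(-c2ccc(NC(=O)CCl)cc2)nc(-c2ccccc2)c1-c1ccccc1`: 53.2%
Compound 2 `Cn1c(-c2ccc(NC(=O)CSc3nc4ccccc4o3)cc2)nc(-c2ccccc2)c1-c1ccccc1`: 79.3%
Compound 3 `CN1CCN(CC(=O)Nc2ccc(-c3nc(-c4ccccc4)c(-c4ccccc4)n3C)cc2)CC1`: 49.1%

Three compounds sharing one core were measured in a functional assay on HT-29 cells (Homo sapiens) for cytotoxicity, read by MTT assay, with a stated time of 24 h, tested at 32 ug/mL; a higher number here means a stronger effect of the compound at the concentration tested, a lower number a weaker effect. Compound 3 gives the smallest of the three numbers, yet its gap to compound 1, a number 4.1 percentage points lower from compound 1 to compound 3 (within the scatter), is within the scatter, so these two cannot be ordered; only compound 2 stands clearly apart, as a number 30.2 percentage points lower from compound 2 to compound 3 (beyond the scatter) shows.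

Compound 4 `CN(C)/C=C/N1CCN(CC(=O)Nc2ccc(-c3nc(-c4ccccc4)c(-c4ccccc4)n3C)cc2)CC1` differs from compound 3 by 2-(dimethylamino)ethenyl in place of methyl on an amine nitrogen in a ring. Among the compounds with values here, no measured step touches this position. The steps of a number 26.1 percentage points higher from compound 1 to compound 2 (beyond the scatter) and a number 4.1 percentage points lower from compound 1 to compound 3 (within the scatter) both replace the chloro on the saturated chain carbon bound to a carbonyl carbon, and a number 30.2 percentage points lower from compound 2 to compound 3 (beyond the scatter) exchanges two groups at that same place. The ring nitrogen that is altered in compound 4 carries a methyl in every measured compound, so the data give neither a direction nor a size for the change.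

With nothing to lean on, the expected step is none beyond the scatter, a number 0.9 percentage points higher from compound 3 to compound 4 (within the scatter), carried with a wide range. Compound 4 is therefore expected to give 50% in this assay, estimated between 33% and 67%.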

Compound 4, a percentage reported as activity, at one concentration (the size of the read-out at that concentration, not a potency): 29.8%
For compound 4 the middle estimate is 20.2 percentage points above the measured one; the whole stated range lies above it.
By their numbers in this assay, from the lowest: compound 4; then compounds 3 and 1 (each within the scatter of the next); then compound 2.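

Within the data shown here, the amine nitrogen in the ring, which carries a methyl in all the earlier compounds, proves not to be a silent place in this assay: 2-(dimethylamino)ethenyl in place of methyl gives a number 19.3 percentage points lower from compound 3 to compound 4 (beyond the scatter). The exchange of chloro for 4-methylpiperazin-1-yl could not be read, but 4-(2-(dimethylamino)ethenyl)piperazin-1-yl at that same place gives a step beyond the scatter, a number 23.4 percentage points lower from compound 1 to compound 4 (beyond the scatter), and against (1,3-benzoxazol-2-yl)sulfanyl the gap widens to a number 49.5 percentage points lower from compound 2 to compound 4 (beyond the scatter), which leaves compound 4 the lowest of the four in this read-out. Nothing available here accounts for the drop, so the step stands as an observation without an explanation.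

The compounds shown do not separate the double bond, the added dimethylamino nitrogen and the larger size of the entering group, and a plain ethyl or a saturated 2-(dimethylamino)ethyl on the same ring nitrogen would begin to tell these apart. On these data alone, it also stays open whether the step holds at other concentrations, as this assay reports the size of the effect at a single concentration and not a potency.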